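Carboxamide to carboxylic acid on the biaryl tail

The source may hold more compounds than are shown below. What is called first, only, known or untested is meant among the compounds shown, and "the series" means these compounds.

Of the compounds shown here, two have been measured in an assay on isolated protein for inhibition of 2-Hydroxyacid oxidase 2 (Homo sapiens), tested at 1 uM; on this read-out lower numbers stand for a weaker effect and higher numbers for a stronger effect at the one concentration tested. Compound 1 `Cc1n[nH]c(C(=O)O)c1Cc1cccc(-c2ccc(C(N)=O)cc2)c1` carries a carbamoyl group on the outer ring of its biaryl tail, and in this assay compound 1 gives 18%. Compound 2 `Cc1n[nH]c(C(=O)O)c1Cc1ccc(-c2ccc(OC(F)(F)F)cc2)cc1` carries a trifluoromethoxy group on the outer ring instead, and in this assay compound 2 gives 11%. The two values lie within the scatter of each other, so neither compound can be set apart from the other on the numbers shown; both read-outs are low at the single concentration tested.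

Compound 3 `Cc1n[nH]c(C(=O)O)c1Cc1cccc(-c2ccc(C(=O)O)cc2)c1` is not yet measured. It differs from compound 1 in one place: hydroxy in place of amino on a carbonyl carbon. Among the compounds with values here, no step between measured compounds matches this change, so no measured guide to its size exists. Given that compound 1 gives 18%, the change is expected to move the read-out by no more than the scatter, in no particular direction, so a number 3 percentage points lower from compound 1 to compound 3 (within the scatter) is expected to be small. Compound 3 is estimated at 15%, with a range from 0% to 35%.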

Compound 3, a percentage reported as inhibition, at one concentration (the size of the read-out at that concentration, not a potency): 3%
Compound 3: middle estimate off by 12 percentage points, on the high side; the measured number falls inside the stated range.
By their numbers in this assay, from the lowest: compounds 3, 2 and 1 (each within the scatter of the next, the first and the last beyond it).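

In this assay, carbamoyl to carboxy, with hydroxy in place of amino on a carbonyl carbon, gives a number 15 percentage points lower from compound 1 to compound 3 (beyond the scatter). Within the data shown here, this is the only step so far, and it lies beyond the scatter, which shows that the read-out at this position responds to an exchange of one heavy atom, even with the counted hydrogen-bond donors and acceptors of the two groups unchanged. No supporting data bear on why the read-out falls with this change, and the step stands as an observation only.

As far as these compounds go, whether a methyl ester or a nitrile in place of the carbamoyl group would read like compound 1 or like compound 3 remains open, as does whether the step is specific to the carboxylic acid or extends to other groups on that carbonyl carbon. All of these values come from one concentration, which gives no potency for compound 1 or compound 3 and leaves open how far the step would carry over to a full concentration-response comparison.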